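The source may hold more compounds than are shown below. What is called first, only, known or untested is meant among the compounds shown, and "the series" means these compounds.

Measured compounds:

compound 1 `Cc1nc(C#Cc2cc(C#N)cc([N+](=O)[O-])c2)cs1` — 0.36 nM in an assay on HEK293 cells for displacement of a labelled ligand from metabotropic glutamate receptor 5 (Rattus norvegicus), read by scintillation counting; on this read-out higher numbers stand for weaker inhibition and lower numbers for stronger inhibition
compound 2 `Cc1nc(C#Cc2cc(F)cc([N+](=O)[O-])c2)cs1` — 0.3 nM in this assay

Within the data shown here, only two compounds have numbers so far, and they differ in a single group on the six-membered aromatic ring. Among the measured compounds shown here, the one measured step, a 1.2-fold lower number from compound 1 to compound 2 (0.08 log units; within the scatter), lies within the scatter, so the two numbers cannot be told apart; compound 2 stands next to compound 1 rather than apart from it.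

Compound 3 `Cc1nc(C#Cc2cc(I)cc([N+](=O)[O-])c2)cs1` has not yet been measured. Its change from compound 2 is iodo in place of fluoro on an aromatic carbon. For the measured compounds named here, the one step that bears on it swapped groups at the same place and moved the number by only a 1.2-fold lower number from compound 1 to compound 2 (0.08 log units; within the scatter), a change within the scatter. On that basis a step in this assay from compound 2 to compound 3 of no more than the scatter is expected, in no particular direction, and the estimated step is a 1.3-fold higher number from compound 2 to compound 3 (0.12 log units; within the scatter). For compound 3 the expected number in this assay is 0.4 nM, with a range from 0.15 nM to 1.2 nM.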

Compound 3, inhibition constant: 1.84 nM
Estimate against measurement, compound 3: 4.6-fold (0.66 log units) below, and the stated range ends below it.
By their numbers in this assay, from the lowest: compounds 2 and 1 (each within the scatter of the next); then compound 3.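

In this assay this position on the six-membered aromatic ring does not accept every group equally: cyano and fluoro could not be told apart, but iodo gives a 6.1-fold higher number from compound 2 to compound 3 (0.79 log units; beyond the scatter) and a 5.1-fold higher number from compound 1 to compound 3 (0.71 log units; beyond the scatter), both modest steps that lie beyond the scatter. The earlier finding therefore applies to that pair of groups and does not extend to all groups at this place, although the change weakens inhibition without abolishing it, as compound 3 still gives 1.84 nM in the same assay. Nothing available here explains why iodo stands apart from fluoro and cyano.

As far as these compounds go, with only these three groups at this position, it remains open whether the higher number is peculiar to iodo or would also appear with chloro or bromo, and how a methoxy group or an amine would fare here. From the compounds shown here alone, it is also open whether iodo would have the same effect if the nitro group meta to it gave way to another group, such as a carboxylic acid.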